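Aryl substitution on a shared core: one-dose inhibition notes

A few compounds are considered here, and "the series" means these few. Any claim that something is new, unique, unknown or untested is made for them only; others in the source may bear on it.

Measured so far:
Compound 1 `Nc1nc(N)nc(-c2cc(F)ccc2Cl)n1` gives 78% in a functional assay on the whole organism with Rattus norvegicus as the target, at a dose of 20 mg/kg by the intraperitoneal route; a lower number here means less inhibition, a higher number more inhibition at the dose given (going by the name of the read-out).
Compound 2 `Nc1nc(N)nc(-c2cccc(F)c2)n1` gives 70% in this assay.
Compound 3 `Nc1nc(N)nc(-c2cc(Br)ccc2F)n1` gives 100% in this assay.

Compound 2 stands lowest of the three numbers; its nearest neighbour is compound 1, within the scatter, and its furthest is compound 3, beyond the scatter. For the measured compounds named here, the one step between compounds differing in a single place is a number 8 percentage points lower from compound 1 to compound 2 (within the scatter), hydrogen in place of chloro on an aromatic carbon, which stayed within the scatter.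

Compound 4 `Nc1nc(N)nc(-c2cccc(SC(F)(F)F)c2)n1` differs from compound 2 by (trifluoromethyl)sulfanyl in place of fluoro on an aromatic carbon. Going by the values given here, the only measured step that bears on it is the one from compound 1 to compound 2, a change on the same aromatic ring that moved the number little. Among the compounds with values here, no measured step swaps a fluoro for a (trifluoromethyl)sulfanyl, so the data give no direction for this change. The expected step is therefore small, a number 4 percentage points higher from compound 2 to compound 4 (within the scatter), not beyond the scatter in either direction. Compound 4 is estimated at 74% in this assay, with a range from 50% to 95%.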

Compound 4, a percentage reported as inhibition, in the whole organism at one dose (the size of the read-out at that dose, not a potency): 87%
Compound 4: middle estimate off by 13 percentage points, on the low side; the measured number falls inside the stated range.
By their numbers in this assay, from the lowest: compounds 2, 1 and 4 (each within the scatter of the next, the first and the last beyond it); then compound 3.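

At this position, on an aromatic carbon of the six-membered ring, the change from fluoro to (trifluoromethyl)sulfanyl gives a number 17 percentage points higher from compound 2 to compound 4 (beyond the scatter) in this assay. For the compounds shown here, this is the first single-place step that lies beyond the scatter, so the read-out at this dose does respond to the group at this place. It also shows that a group of 5 heavy atoms can stand here in place of a single fluorine with no loss in the number; no measurement given bears on the reason for the rise.

Still open, from the compounds shown here alone, is whether the rise belongs to the sulfur link or to the trifluoromethyl part, which a plain trifluoromethyl or a methylsulfanyl at the same place would separate. Going by these compounds, how an amine or a carboxylic acid would behave at this place is also open.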